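The source may hold more compounds than are shown below. What is called first, only, known or untested is meant among the compounds shown, and "the series" means these compounds.

Among the compounds with values here, compound 1 `Cc1ccc(C)c(-c2nc(CN3CCC(C(=O)NCCCN4C[C@H](C)C[C@H](C)C4)CC3)c(C)o2)c1` is one of two compounds measured in an ADME assay on Huh7.5.1 cells (Homo sapiens) for cytotoxicity, read by ATP content, with a stated time of 48 h (on this read-out lower numbers stand for higher toxicity in this test and higher numbers for lower toxicity in this test), and compound 1 gives 4070 nM, the lowest of the two numbers. Compound 2 `Cc1ccccc1-c1nc(CN2CCC(C(=O)NCCN3C[C@H](C)C[C@H](C)C3)CC2)c(C)o1` gives 24400 nM in this assay, a gap beyond the scatter; compound 2 differs from compound 1 in more than one place, so no single step is shown. Compound 3 `Cc1ccc(-c2nc(CN3CCC(C(=O)NCCCN4C[C@H](C)C[C@H](C)C4)CC3)c(C)o2)cc1` differs from compound 1 by 4-methylphenyl in place of 2,5-dimethylphenyl on an aromatic carbon. Within the data shown here, with no step between measured compounds, a small rise in compound 3 is expected, a 1.5-fold higher number from compound 1 to compound 3 (0.17 log units; within the scatter), possibly within the scatter. Compound 3 is thus estimated at 6000 nM, between 2500 nM and 15000 nM.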

Compound 3, half-maximal cytotoxic concentration: 4330 nM
Beside the measured number, compound 3's estimate is 1.4-fold (0.14 log units) above it, and the stated range covers the measured number.
By their numbers in this assay, from the lowest: compounds 1 and 3 (each within the scatter of the next); then compound 2.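

In this assay, within the data shown here, 4-methylphenyl in place of 2,5-dimethylphenyl on this aromatic carbon gives a 1.1-fold higher number from compound 1 to compound 3 (0.03 log units; within the scatter), the first single-place comparison. At this position, the two substituted phenyl groups cannot be told apart by this read-out. No available data explain this result.

From the compounds shown here alone, it remains open whether a group of another kind here, such as a pyridine ring, a phenyl ring bearing a carboxylic acid or an amine, or a cyclohexyl ring, would move the number beyond the scatter.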